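Removing the propyl side chain from a legumain inhibitor

A few compounds are considered here, and "the series" means these few. Any claim that something is new, unique, unknown or untested is made for them only; others in the source may bear on it.

Measured so far:
compound 1, `C[C@@H](C(=O)N[C@H](C#N)CC(N)=O)N(Cc1ccc(-c2cc(F)cc(F)c2)cc1)S(C)(=O)=O`, 1360 nM
compound 2, `CCC[C@@H](C(=O)N[C@H](C#N)CC(N)=O)N(Cc1ccc(-c2cccc(F)c2F)cc1)S(C)(=O)=O`, 7750 nM

Both compounds were tested in an assay on isolated protein for inhibition of legumain (Homo sapiens), with stated times of 2 min and 60 min; on this read-out lower numbers stand for stronger inhibition and higher numbers for weaker inhibition. Compound 2 has the higher of the two numbers, and the gap to compound 1 lies beyond the usual scatter of repeated measurements. The two compounds differ in more than one place, so no single change can be tied to that gap; only the two values themselves can be compared.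

Compound 3, `CS(=O)(=O)N(CC(=O)N[C@H](C#N)CC(N)=O)Cc1ccc(-c2cccc(F)c2F)cc1`, has not yet been measured in this assay. It differs from compound 2 in one place: hydrogen in place of propyl on a saturated chain carbon bound to a carbonyl carbon and a sulfonamide nitrogen. Compound 1, which carries a smaller group at this carbon, gives the lower number, but its differing fluorine pattern means this is not a clean guide. The step from compound 2 to compound 3 is therefore expected to be modest, in the direction of a lower number, at a 2.6-fold lower number from compound 2 to compound 3 (0.41 log units; beyond the scatter), and compound 3 is estimated to give 3000 nM, with a range of 800 nM to 12000 nM.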

Compound 3, half-maximal inhibitory concentration: > 10000 nM
Compound 3: a limit, no number; the forecaster's own chance of this, stated with the estimate: 10%; middle value at least 3.3-fold (0.52 log units) from the limit.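

In this assay compound 3 gives > 10000 nM, which is a limit of the assay and not a number, so the reading marks only where the measurable range ends: the limit of > 10000 nM in this assay, at which 1 of the 3 values shown sits.

Placing hydrogen in place of propyl on the saturated chain carbon bound to a carbonyl carbon and a sulfonamide nitrogen gives an at least 1.2-fold higher number from compound 2 to compound 3 (0.11 log units; that floor lies within the scatter). On these data alone, that floor is all the pair can state, so the true size of the step remains unknown, and the change may be small or much larger. Even so, this is the first view of this carbon on its own, since the earlier pair differs in more than one place, and here losing the propyl group brings no sign of stronger inhibition.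

The compounds shown leave open how far the number actually rises from compound 2 to compound 3, a question that only a reading inside the measurable range could settle. They also leave open what a butyl chain, or a chain ending in an amine, would give at this same carbon on the core of compound 2.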